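Piperidine to methylpiperazine on a quinoline ether chain

This account rests on a few compounds, and the source may have more. Where it says the series, first, only, none or still open, it means among the compounds named here.

Two compounds share a core and are compared in a functional assay on NCI-H460 cells (Homo sapiens) for inhibition, read by MTT assay, with a stated time of 72 h; a higher number here means a weaker inhibitor, a lower number a stronger inhibitor. Compound 1, `COc1cc2c(Oc3ccc(NC(=O)c4nn(-c5ccccc5OC(F)(F)F)c(=O)cc4C)cc3F)ccnc2cc1OCCCN1CCN(C)CC1`, gives 260 nM. Compound 2, `COc1ccc(-n2nc(C(=O)Nc3ccc(Oc4ccnc5cc(OCCCN6CCCCC6)c(OC)cc45)c(F)c3)c(C)cc2=O)cc1`, gives 3730 nM, the higher of the two numbers, and the gap between compound 1 and compound 2 lies beyond the scatter; since the two differ in more than one place, no single change can be tied to that gap. Compound 3, `COc1ccc(-n2nc(C(=O)Nc3ccc(Oc4ccnc5cc(OCCCN6CCN(C)CC6)c(OC)cc45)c(F)c3)c(C)cc2=O)cc1`, has not been measured. It differs from compound 2 in one place: 4-methylpiperazin-1-yl in place of piperidin-1-yl on a saturated chain carbon, three bonds along the chain from an oxygen on an aromatic ring. Going by the values given here, no measured pair shows this exact change on its own, so the step to compound 3 rests on expectation only. Compound 3 is expected to give 2000 nM, within a range from 700 nM to 6000 nM. That estimate means an expected step of a 1.9-fold lower number from compound 2 to compound 3 (0.27 log units; within the scatter), a modest move toward a lower number that may not clear the usual scatter.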

Compound 3, half-maximal inhibitory concentration: 3660 nM
Compound 3: middle estimate off by 1.8-fold (0.26 log units), on the low side; low and high end bracket the measured number.
By their numbers in this assay, from the lowest: compound 1; then compounds 3 and 2 (each within the scatter of the next).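

In this assay, 4-methylpiperazin-1-yl in place of piperidin-1-yl, on a saturated chain carbon three bonds along the chain from an oxygen on an aromatic ring, reads as a 1.0-fold lower number from compound 2 to compound 3 (0.01 log units; within the scatter) and so the two rings cannot be told apart here. Compound 3 also isolates a second change, 4-methoxyphenyl in place of 2-(trifluoromethoxy)phenyl on an aromatic nitrogen, which reads as a 14-fold higher number from compound 1 to compound 3 (1.15 log units; beyond the scatter). So the large gap between compound 1 and compound 2 tracks the group on that nitrogen, not the ring on the chain. Nothing measured here explains either result.

Still open, from the compounds shown here alone, is whether a morpholine ring, a dimethylamino group or a shorter chain would match these two rings in the same place. Also open, going by these compounds, is whether piperidin-1-yl and 4-methylpiperazin-1-yl would still match with 2-(trifluoromethoxy)phenyl on the aromatic nitrogen.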